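This account rests on a few compounds, and the source may have more. Where it says the series, first, only, none or still open, it means among the compounds named here.

Working notes on the series.

Compound 1 `CCN(CC)CCn1c(N)c(-c2nc3ccccc3[nH]2)c2nc(C#N)c(C#N)nc21` is the reference point. In a functional assay on HL60/MX2 cells (Homo sapiens) for antiproliferative activity, read by MTT assay, with a stated time of 48 h (a lower number here means a stronger inhibitor, a higher number a weaker inhibitor), compound 1 gives 7150 nM. Compound 2 `CN(C)CCCn1c(N)c(-c2nc3ccccc3[nH]2)c2nc(C#N)c(C#N)nc21` differs from compound 1 by (dimethylamino)methyl in place of diethylamino on a saturated chain carbon, two bonds along the chain from an aromatic nitrogen; in this assay compound 2 gives 2390 nM, a step of a 3.0-fold lower number from compound 1 to compound 2 (0.48 log units; beyond the scatter). Compound 3 `CCN(CC)CCn1c(N)c(-c2nc3ccccc3n2C)c2nc(C#N)c(C#N)nc21` carries a core that differs from the core of compound 1 by methyl in place of hydrogen on an aromatic nitrogen; in this assay compound 3 gives 3250 nM, a step of a 2.2-fold lower number from compound 1 to compound 3 (0.34 log units; beyond the scatter). Within the data shown here, no step is computed between compound 2 and compound 3; their two values lie within the usual scatter of one another, so nothing is said about their order.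

Compound 4 `CN(C)CCCn1c(N)c(-c2nc3ccccc3n2C)c2nc(C#N)c(C#N)nc21` has not yet been measured in this assay. It differs from compound 3 by (dimethylamino)methyl in place of diethylamino on a saturated chain carbon, two bonds along the chain from an aromatic nitrogen. This is the same change as that from compound 1 to compound 2, where the place described is identical word for word, and there it made a 3.0-fold lower number from compound 1 to compound 2 (0.48 log units; beyond the scatter). Whether that step carries over onto the core of compound 3 rests on a single earlier example, so some caution is in order. Among the measured compounds shown here, for compound 4 a step of a 2.5-fold lower number from compound 3 to compound 4 (0.40 log units; beyond the scatter) is expected, set beside the earlier one, because the only precedent is a 3.0-fold lower number from compound 1 to compound 2 (0.48 log units; beyond the scatter). On that basis compound 4 is estimated to give 1300 nM in this assay, with an expected range from 600 nM to 3300 nM.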

Compound 4, half-maximal inhibitory concentration: 11300 nM
Compound 4: middle estimate off by 8.7-fold (0.94 log units), on the low side, and the stated range ends below it.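

Carried onto the core bearing methyl on an aromatic nitrogen, the change from diethylamino to (dimethylamino)methyl reverses direction in this assay, with a 3.5-fold higher number from compound 3 to compound 4 (0.54 log units; beyond the scatter), so the earlier step does not transfer between these two cores: the same change on two cores in this assay, a 3.0-fold lower number (0.48 log units; beyond the scatter) from compound 1 to compound 2 and a 3.5-fold higher number (0.54 log units; beyond the scatter) from compound 3 to compound 4, 10-fold (1.02 log units) apart, beyond the scatter of two such steps

Read the other way round, methyl in place of hydrogen on an aromatic nitrogen also gives a result that depends on the side chain, with a 4.7-fold higher number from compound 2 to compound 4 (0.67 log units; beyond the scatter), and this does not match its effect with the diethylamino side chain: the same change on two cores in this assay, a 2.2-fold lower number (0.34 log units; beyond the scatter) from compound 1 to compound 3 and a 4.7-fold higher number (0.67 log units; beyond the scatter) from compound 2 to compound 4, 10-fold (1.02 log units) apart, beyond the scatter of two such steps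

The two changes are therefore not additive across these four compounds, and a step measured on one core is a poor guide to the same step on the other; what this does not show is why they interact, or whether the reversal holds beyond this single pair of pairs.

Still open is whether the interaction follows the chain length or the substituents on the amine, as the compounds shown change both together; a 2-(dimethylamino)ethyl or a 3-(diethylamino)propyl chain on each core would separate the two. Also open, as far as these compounds go, is whether an ethyl group in place of the methyl on the aromatic nitrogen, or a cyclic amine such as morpholine at the chain end, would follow compound 3 and compound 4 or depart from them.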